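The source may report more compounds than this note shows. Statements on the series, on what has been measured and on what is new or still open speak of the compounds shown alone.

Measured so far:
- compound 1 `COc1nc2ccc(Br)cc2cc1C(c1ccccc1)n1cc(C2CC2)nn1`: 22.6%
- compound 2 `COc1nc2ccc(Br)cc2cc1C(c1ccccc1)n1cc(-c2ccc(Br)cc2)nn1`: 7.43%

Among the compounds with values here, in an ADME assay on PC-3 cells (Homo sapiens) for cytotoxicity, read by sulforhodamine B assay, with a stated time of 48 h, tested at 10 uM (on this read-out lower numbers stand for less inhibition and higher numbers for more inhibition at the one concentration tested (going by the name of the read-out)), compound 2 stands lowest of the two numbers; the only step, a number 15.2 percentage points lower from compound 1 to compound 2 (beyond the scatter), lies beyond the scatter. Compound 3 `COc1nc2ccc(Br)cc2cc1C(c1ccccc1)n1cc(-c2cccc(F)c2)nn1` differs from compound 2 by 3-fluorophenyl in place of 4-bromophenyl on an aromatic carbon. Within the data shown here, no measured step exchanges one aryl group for another, so the single step on hand, a number 15.2 percentage points lower from compound 1 to compound 2 (beyond the scatter), bears only loosely on this change. The expected step of a number 2.6 percentage points higher from compound 2 to compound 3 (within the scatter) is therefore small, within the scatter, in no firm direction. For compound 3 the estimate in this assay is 10%, from 0% to 24%.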

Compound 3, a percentage reported as inhibition, at one concentration (the size of the read-out at that concentration, not a potency): 14.6%
Compound 3: the middle estimate sits 4.6 percentage points below what was measured; the range from low to high includes it.
By their numbers in this assay, from the lowest: compounds 2, 3 and 1 (each within the scatter of the next, the first and the last beyond it).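

In this assay, an exchange of one aryl group for another at this carbon gives a number 7.2 percentage points higher from compound 2 to compound 3 (within the scatter), so 3-fluorophenyl and 4-bromophenyl are not separated here. Replacing cyclopropyl with an aryl group therefore does not always give a step beyond the scatter: 3-fluorophenyl gives a number 8 percentage points lower from compound 1 to compound 3 (within the scatter). No measured evidence bears on the origin of these numbers. Going by these compounds, whether the halogen or its ring place matters remains open, since both change together. Also open, on these data alone, is how an aminomethyl or carboxylic acid group at this carbon would read.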